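Trimming the Side Chain on a Piperazine-Bearing Core

The source may hold more compounds than are shown below. What is called first, only, known or untested is meant among the compounds shown, and "the series" means these compounds.

Of the compounds shown here, two sharing one core have been measured in a functional assay on HL-60 cells (Homo sapiens) for inhibition, read by MTT assay, with a stated time of 72 h; on this read-out higher numbers stand for weaker inhibition and lower numbers for stronger inhibition. Compound 1 `CCCCCC(=O)N1CCN(c2nnc3nncn3n2)CC1` gives 3610 nM, the lower of the two numbers and so the stronger inhibition seen here. Compound 2 `CCCNc1nnc2nncn2n1`, which carries a propylamino group on the core in place of the piperazine, gives 15100 nM, a number higher than that of compound 1 by a gap beyond the usual scatter of repeated measurements.

Compound 3 `CN1CCN(c2nnc3nncn3n2)CC1` has not yet been measured. It differs from compound 1 at a single place: methyl in place of pentylcarbonyl on an amine nitrogen in a ring. The pentylcarbonyl leaves and a methyl enters on the amine nitrogen in the ring. Within the data shown here, no measured pair differs in exactly this way, so the size of this step cannot be read directly from the data. Among the measured compounds shown here, the only guide is that compound 2, the compound with less attached to the core, gives 15100 nM while compound 1 gives 3610 nM. On that basis compound 3 is expected to show weaker inhibition than compound 1, with a step of a 2.5-fold higher number from compound 1 to compound 3 (0.40 log units; beyond the scatter) that would fall beyond the scatter. Compound 3 is estimated to give about 9000 nM, within a likely range from 2500 nM to 30000 nM.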

Compound 3, half-maximal inhibitory concentration: 8540 nM
Compound 3: the middle estimate sits 1.1-fold (0.02 log units) above what was measured, and the stated range covers the measured number.
By their numbers in this assay, from the lowest: compound 1; then compounds 3 and 2 (each within the scatter of the next).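

In this assay, replacing the pentylcarbonyl on the ring's amine nitrogen with a methyl gives a 2.4-fold higher number from compound 1 to compound 3 (0.37 log units; beyond the scatter). Among these compounds, this modest step lies beyond the usual scatter, and it is the first direct sign that the group on this nitrogen affects the read-out, since 7 heavy atoms leave and only 1 enters, yet compound 3 still gives a measurable 8540 nM. Nothing available explains the size of this step.

The single change removes the carbonyl and shortens the chain together, so the compounds shown cannot say which of the two matters, and a plain pentyl or a small acetyl on the same nitrogen would help to pull these two apart. Going by these compounds, it also remains open whether the trend runs any further in the other direction, as a longer chain such as octanoyl on this nitrogen could either strengthen inhibition beyond that of compound 1 or show that the benefit of a larger group has already levelled off.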